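Amide variation on the hexafluoro-carbinol naphthalene core

The compounds below may be only part of what the source reports. "The series", "measured", "known", "first", "only" and "open" are said of these compounds alone.

Measured compounds:
- compound 1, `CC(=O)Nc1c(C(O)(C(F)(F)F)C(F)(F)F)ccc2ccccc12`: 87%
- compound 2, `O=C(Nc1c(C(O)(C(F)(F)F)C(F)(F)F)ccc2ccccc12)c1cccc([N+](=O)[O-])c1`: 99%
- compound 3, `O=C(Nc1c(C(O)(C(F)(F)F)C(F)(F)F)ccc2ccccc12)c1ccc(Cl)cc1`: 99%

All three share the same core and differ only in the group on the carbonyl carbon of the amide. In a functional assay (Sus scrofa) with sulfonylurea receptors; K-ATP channels (Homo sapiens) as the target (on this read-out lower numbers stand for smaller maximal responses and higher numbers for larger maximal responses), compound 1 sits lowest of the three numbers, with compound 2 and compound 3 both above it. The two steps that replace the methyl with an aromatic ring, a number 12 percentage points higher from compound 1 to compound 2 (beyond the scatter) and a number 12 percentage points higher from compound 1 to compound 3 (beyond the scatter), are alike in size and direction, and between the two aryl amides there is no change at the digits printed from compound 2 to compound 3 (within the scatter).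

Compound 4, `O=C(Nc1c(C(O)(C(F)(F)F)C(F)(F)F)ccc2ccccc12)c1ccco1`, is not yet measured. It differs from compound 1 as follows:

furan-2-yl in place of methyl on a carbonyl carbon

Both measured steps from compound 1 that introduce an aromatic ring on the carbonyl carbon bear on this change, and each moved the maximal response upward by a modest amount beyond the scatter. A five-membered aromatic ring in place of methyl is therefore expected to behave in the same way, giving a step of a number 10 percentage points higher from compound 1 to compound 4 (within the scatter) that is estimated to be upward and modest. Compound 4 is thus expected to reach about 97% in this assay, with a range from 86% to 102%.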

Compound 4, largest response reached (reported as efficacy), in percent of the reference or control that the assay uses: 96%
For compound 4 the middle estimate is 1 percentage points above the measured one; the measured number falls inside the stated range.
By their numbers in this assay, from the lowest: compounds 1, 4, 2 and 3 (each within the scatter of the next, the first and the last beyond it).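

In this assay, furan-2-yl in place of methyl on the carbonyl carbon gives a number 9 percentage points higher from compound 1 to compound 4 (within the scatter) and so, unlike 3-nitrophenyl and 4-chlorophenyl, does not clear the scatter against methyl. The comparisons with the two aryl amides also stay inside the scatter, with a number 3 percentage points lower from compound 3 to compound 4 (within the scatter) and a number 3 percentage points lower from compound 2 to compound 4 (within the scatter), so compound 4 cannot be separated from compound 1, compound 2 or compound 3 on this read-out. The position therefore tolerates a five-membered aromatic ring with 1 hetero atom and 1 hydrogen-bond acceptor without any loss that can be resolved, and only the methyl amide and the two aryl amides stand apart beyond the scatter.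

The compounds shown leave open whether an aromatic ring is needed here at all, since a longer alkyl chain or a saturated ring such as tetrahydrofuran-2-yl would test that directly. It also remains open how an aminomethyl group or a carboxylic acid on the aryl ring would read, and nothing shown offers a reason for any of these steps.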